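Swapping a pyridinyl group for a chlorophenyl group

A few compounds are considered here, and "the series" means these few. Any claim that something is new, unique, unknown or untested is made for them only; others in the source may bear on it.

Compound 1 `Cc1cccc(-c2cc(-c3ccc(Cl)o3)cc(-c3ccsc3)n2)c1` gives 7.5% in an assay on isolated protein for inhibition of DNA topoisomerase 1 (Homo sapiens), tested at 100 uM; a higher number here means a stronger effect of the compound at the concentration tested, a lower number a weaker effect.
Compound 2 `Clc1ccc(-c2cc(-c3cccnc3)nc(-c3cccs3)c2)o1` gives 25.8%.
Compound 3 `Cc1ccccc1-c1cc(-c2ccc(Cl)o2)cc(-c2ccsc2)n1` gives 6.7%.

Among these three, compound 2 stands highest in this assay, and the gaps down to compound 1 and to compound 3 both lie beyond the usual scatter. Compound 4 `Clc1ccc(-c2cc(-c3cccs3)nc(-c3ccccc3Cl)c2)o1` is not yet measured; it differs from compound 2 in a single place: 2-chlorophenyl in place of pyridin-3-yl on an aromatic carbon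

Among the measured compounds shown here, only one step between measured compounds is available, a number 0.8 percentage points lower from compound 1 to compound 3 (within the scatter), and it concerns two methylphenyl groups on a core that is not the core of compound 2, so it does not bear directly on the change at hand. It does show that moving a methyl group around a phenyl ring made no difference beyond the scatter. Compounds 1 and 3, which carry a phenyl-type group where compound 2 carries pyridin-3-yl, both sit low, but they differ from compound 2 in more than one place, so they give only a loose hint that removing the pyridinyl group may cost some inhibition.

Compound 4 is therefore expected to lie below compound 2, with an estimated step of a number 12.8 percentage points lower from compound 2 to compound 4 (beyond the scatter) in this assay. The estimate for compound 4 is 13%, within a range of 2% to 28%.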

Compound 4, a percentage reported as inhibition, at one concentration (the size of the read-out at that concentration, not a potency): 41.3%
Estimate against measurement, compound 4: 28.3 percentage points below; the whole stated range lies below it.
By their numbers in this assay, from the lowest: compounds 3 and 1 (each within the scatter of the next); then compound 2; then compound 4.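

In this assay, the position next to the ring nitrogen, meta to a 5-chlorofuran-2-yl group and meta to a thiophen-2-yl group, now has its first direct reading, and the change moves the number upward: a number 15.5 percentage points higher from compound 2 to compound 4 (beyond the scatter). The step is modest, but it shows that in this pair, inhibition at the tested concentration does not depend on the nitrogen of pyridin-3-yl or its hydrogen-bond acceptor, since 2-chlorophenyl, a ring of carbon only with no hydrogen-bond acceptor, gives the higher number. Nothing measured here gives a reason for the rise.

This single swap removes a ring nitrogen and adds a chlorine in one move, so the compounds shown cannot tell which of the two goes with the rise; plain phenyl at this position would separate them. They also leave open how this position responds to other kinds of group, such as a methoxy group or a carboxylic acid on the ring, and whether the rise would carry over to a different core.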